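The source may hold more compounds than are shown below. What is called first, only, known or untested is meant among the compounds shown, and "the series" means these compounds.

The series shares one core and differs only in the substitution of its fused aromatic part. Compound 1 `O=c1c(-c2cccc([N+](=O)[O-])c2)nc2ccccc2n1Cc1ccccc1` carries no substituent there, and in an assay on cells for activation of Cystic fibrosis transmembrane conductance regulator (Homo sapiens), read by fluorescence, with a stated time of 10 min (a lower number here means that less compound is needed, a higher number that more compound is needed for the effect), compound 1 gives 9 nM. Compound 2 `O=c1c(-c2cccc([N+](=O)[O-])c2)nc2ccc(Cl)cc2n1Cc1ccccc1` bears a chloro group, and in this assay compound 2 gives 760 nM. Compound 3 `O=c1c(-c2cccc([N+](=O)[O-])c2)nc2cc(Cl)ccc2n1Cc1ccccc1` bears a chloro group at a different position of the same ring, and in this assay compound 3 gives 70 nM, which places it second highest of the three numbers, with compound 1 as nearest neighbour and compound 2 furthest away.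

Compound 4 `O=c1c(-c2cccc([N+](=O)[O-])c2)nc2cc(Cl)c(Cl)cc2n1Cc1ccccc1` is compound 3 with a further change: chloro in place of hydrogen on an aromatic carbon. The added chloro group occupies the position that distinguishes compound 2 from compound 1. Among the measured compounds shown here, two measured steps bear on this. The step of an 84-fold higher number from compound 1 to compound 2 (1.93 log units; beyond the scatter) was large, while the step of a 7.8-fold higher number from compound 1 to compound 3 (0.89 log units; beyond the scatter) was modest. Since compound 4 combines both substitutions, a step of size a 43-fold higher number from compound 3 to compound 4 (1.63 log units; beyond the scatter) toward a higher number is expected, in line with the large step seen from compound 1 to compound 2. Compound 4 is therefore estimated at 3000 nM in this assay, with a range from 500 nM to 20000 nM.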

Compound 4, half-maximal effective concentration: > 10000 nM
Compound 4 was reported as a limit (the forecaster's own chance of this, stated with the estimate: 15%); at least 3.3-fold (0.52 log units) between middle value and limit.
By their numbers in this assay, from the lowest: compound 1; then compound 3; then compound 2. At a limit, above all of these: compound 4.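

Compound 4 stands at a limit of the assay rather than at a number: in this assay compound 4 gives > 10000 nM. The cost of a chloro group on this aromatic carbon is not confined to the unsubstituted core, for it persists when the new group sits ortho to a chloro group already present, with an at least 140-fold higher number from compound 3 to compound 4 (2.15 log units; beyond the scatter), so both cores show a large rise in the number needed for the effect: the same change on two cores in this assay, an 84-fold higher number (1.93 log units; beyond the scatter) from compound 1 to compound 2 and an at least 140-fold higher number (2.15 log units; beyond the scatter) from compound 3 to compound 4; the limit leaves it open whether they differ. Nor does the first chloro group rescue the second, since adding the other chloro group to the already weakened compound 2 still gives an at least 13-fold higher number from compound 2 to compound 4 (1.11 log units; beyond the scatter), and the two substitutions thus pull in the same direction on either route: the same change on two cores in this assay, a 7.8-fold higher number (0.89 log units; beyond the scatter) from compound 1 to compound 3 and an at least 13-fold higher number (1.11 log units; beyond the scatter) from compound 2 to compound 4; the limit leaves it open whether they differ.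

With the top of the scale reached, the compounds shown leave open whether the two chloro groups merely add up or together cost more than the sum of their separate steps. They also leave open whether this aromatic carbon rejects substitution as such or chloro in particular, since a methoxy group, an amine or a single fluorine there would separate those two readings.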